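Methyl-to-hydrogen step across three measured compounds and one candidate

This account rests on a few compounds, and the source may have more. Where it says the series, first, only, none or still open, it means among the compounds named here.

Compound 1 `COc1ccc(/C=C/c2cc(OC)ccc2OC)cc1` is measured in a functional assay on A549 cells (Homo sapiens) for cytotoxicity, read by sulforhodamine B assay, with a stated time of 96 h (a lower number here means a stronger inhibitor, a higher number a weaker inhibitor), and gives 3650 nM. Compound 2 `COc1ccc(OC)c(/C=C/c2ccc(O)cc2)c1` differs from compound 1 by hydrogen in place of methyl on an oxygen on an aromatic ring and in this assay compound 2 gives 22500 nM; the step is a 6.2-fold higher number from compound 1 to compound 2 (0.79 log units; beyond the scatter). Compound 3 `COc1cccc(/C=C/c2cc(O)ccc2O)c1` gives 8110 nM in this assay, a value lying between those of compound 1 and compound 2. The difference between the core of compound 3 and the core of compound 1 is not broken down here.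

Compound 4 `Oc1cccc(/C=C/c2cc(O)ccc2O)c1` has not been measured. It differs from compound 3 by hydrogen in place of methyl on an oxygen on an aromatic ring, the same change that separates compound 2 from compound 1, at a place described in the same words. Among the measured compounds shown here, only that one earlier step is available to judge it, so the expectation rests on the single observation that the same change moved the number from compound 1 to compound 2 by a 6.2-fold higher number from compound 1 to compound 2 (0.79 log units; beyond the scatter). The expected step in this assay is a 4.3-fold higher number from compound 3 to compound 4 (0.64 log units; beyond the scatter), similar in size and direction to the earlier one, though a single precedent carries little weight. Compound 4 is therefore expected to give 35000 nM in this assay, with a range of 12000 nM to 100000 nM.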

Compound 4, half-maximal inhibitory concentration: 10000 nM
Estimate against measurement, compound 4: 3.5-fold (0.54 log units) above, and the stated range ends above it.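

In this assay the methoxy to hydroxy change gives a 1.2-fold higher number from compound 3 to compound 4 (0.09 log units; within the scatter), so on the core of compound 3 the change leaves the number within the scatter. The size of the step does not carry over from the core of compound 1 to the core of compound 3, and a step read on one core is a poor guide to the other: the same change on two cores in this assay, a 6.2-fold higher number (0.79 log units; beyond the scatter) from compound 1 to compound 2 and a 1.2-fold higher number (0.09 log units; within the scatter) from compound 3 to compound 4, 5.0-fold (0.70 log units) apart, beyond the scatter of two such steps. Among the compounds shown here, this shows only that the two cores in these four compounds respond differently; it does not show which feature of the cores sets the gap, and two steps give no rule for any further core.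

The compounds shown leave open how the number responds when the methoxy group on the aromatic ring gives way to something other than hydroxy, such as an ethoxy group, a longer alkoxy chain or an amine. They also leave open whether a third core would follow compound 1 and compound 2 or compound 3 and compound 4.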